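Cyclohexyl in Place of Phenyl on the Ring Nitrogen

The compounds below may be only part of what the source reports. "The series", "measured", "known", "first", "only" and "open" are said of these compounds alone.

Measured compounds:
compound 1 `Nc1ccccc1NC(=O)c1ccc(CSC(=S)N2CCN(c3ccccc3)CC2)cc1` — 42.3%
compound 2 `Nc1ccccc1NC(=O)c1ccc(CSC(=S)N2CCCC2)cc1` — 27%

Of the compounds shown here, two have been measured in a functional assay on MGC-803 cells (Homo sapiens) for antiproliferative activity, read by CCK-8 assay, with a stated time of 72 h, tested at 2 uM; on this read-out lower numbers stand for a weaker effect and higher numbers for a stronger effect at the one concentration tested. Compound 1 gives 42.3%, the highest of the two numbers; compound 2 gives 27%, a number lower than that of compound 1 by more than the usual scatter. Compound 3 `Nc1ccccc1NC(=O)c1ccc(CSC(=S)N2CCN(C3CCCCC3)CC2)cc1` has not yet been measured in this assay. It differs from compound 1 in one place: cyclohexyl in place of phenyl on an amine nitrogen in a ring. For the measured compounds named here, no pair of measured compounds shows a change of this kind, so the two values at hand give no direct guide to its size. With only compound 1 and compound 2 known, the expected step from compound 1 to compound 3 in this assay is a number 2.3 percentage points lower from compound 1 to compound 3 (within the scatter), which is taken as none beyond the scatter. For compound 3 the estimated value in this assay is 40%, with a range from 22% to 58%.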

Compound 3, a percentage reported as inhibition, at one concentration (the size of the read-out at that concentration, not a potency): 16.9%
Beside the measured number, compound 3's estimate is 23.1 percentage points above it; the measured number lies below the stated range.
By their numbers in this assay, from the lowest: compound 3; then compound 2; then compound 1.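

In this assay, the group on the amine nitrogen in the ring proves to matter: cyclohexyl in place of phenyl gives a number 25.4 percentage points lower from compound 1 to compound 3 (beyond the scatter), so this position does not accept every six-carbon ring alike. The two groups match in heavy atoms and carbon count, and neither carries a hydrogen-bond donor, a hydrogen-bond acceptor or a net charge, so among the features counted here, the one that differs is a six-membered aromatic ring giving way to a non-aromatic one. Nothing at hand explains why the change has this effect.

The compounds shown leave open whether a pyridine ring or a benzyl group on the same nitrogen would behave like phenyl or like cyclohexyl. They also leave open how a fluorine or methoxy group on the phenyl ring of compound 1 would shift the number.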